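The source may hold more compounds than are shown below. What is called first, only, known or untested is meant among the compounds shown, and "the series" means these compounds.

Within the data shown here, in a functional assay on EKVX cells (Homo sapiens) for inhibition, read by sulforhodamine B assay, with a stated time of 48 h (on this read-out lower numbers stand for stronger inhibition of growth and higher numbers for weaker inhibition of growth), compound 1 `O=C(Cc1csc2nc(-c3ccc(Br)cc3)cn12)N/N=C/c1ccccc1` gives 6920 nM and compound 2 `O=C(Cc1csc2nc(-c3ccc(Br)cc3)cn12)N/N=C/c1ccccc1O` gives 3890 nM with the two numbers lying within the scatter of each other, so compound 2 stands level with the only other measured compound. Compound 3 `O=C(Cc1csc2nc(-c3ccc(Br)cc3)cn12)N/N=C/c1ccc(O)cc1` differs from compound 2 by a single change, 4-hydroxyphenyl in place of 2-hydroxyphenyl on a carbon with a double bond to nitrogen in words 4-hydroxyphenyl in place of 2-hydroxyphenyl on a carbon with a double bond to nitrogen. Among the measured compounds shown here, only one measured step bears on this, the one with hydroxy in place of hydrogen on an aromatic carbon on going to compound 2, a 1.8-fold lower number from compound 1 to compound 2 (0.25 log units; within the scatter) and it stayed small. For the measured compounds named here, no measured pair shows what moving the hydroxy does, so no step beyond the scatter is expected in this assay and the expected size is a 1.2-fold higher number from compound 2 to compound 3 (0.06 log units; within the scatter) as estimated here. For compound 3 the estimated value is 4500 nM with an expected range from 2000 nM to 10000 nM on this read-out.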

Compound 3, concentration for 50% growth inhibition: 11500 nM
Beside the measured number, compound 3's estimate is 2.6-fold (0.41 log units) below it, outside the stated range (above it).
By their numbers in this assay, from the lowest: compounds 2, 1 and 3 (each within the scatter of the next, the first and the last beyond it).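

In this assay, 4-hydroxyphenyl in place of 2-hydroxyphenyl on a carbon with a double bond to nitrogen gives a 3.0-fold higher number from compound 2 to compound 3 (0.47 log units; beyond the scatter), so the two hydroxyphenyl groups can be told apart at this place even though their counted features are the same. Hydroxy in place of hydrogen gives a 1.7-fold higher number from compound 1 to compound 3 (0.22 log units; within the scatter), which, like the earlier step to compound 2, stays within the scatter, so the only step beyond it here is the one between the two hydroxyphenyl compounds. Nothing available here accounts for that difference.

On these data alone, it remains open whether a methoxy group, an amine or a carboxylic acid in place of the hydroxy would keep the same difference between these two forms of the ring. As far as these compounds go, it is also open whether the difference would hold with another group in place of the bromine on the shared core.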